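Swapping the aroyl group on a thiosemicarbazide series

The source may hold more compounds than are shown below. What is called first, only, known or untested is meant among the compounds shown, and "the series" means these compounds.

Compound 1, `COc1cc2ncnc(NNC(=S)NC(=O)c3ccc(Cl)cc3)c2cc1OC`, carries a (4-chlorophenyl)carbonyl group on the thiosemicarbazide chain that hangs from its core. In a functional assay on GLC82 cells (Homo sapiens) for cytotoxicity, read by MTT assay, with a stated time of 72 h (on this read-out lower numbers stand for stronger inhibition and higher numbers for weaker inhibition), compound 1 gives 9620 nM. Compound 2, `O=C(NC(=S)NNc1ncnc2ccccc12)c1ccc(Cl)cc1`, shares the chain but lacks the two methoxy groups on the core, and in this assay compound 2 gives 6680 nM; the two numbers sit within the usual scatter of each other, so they show no real difference. Of the two values, that of compound 1 is the higher one, but only by a margin that repeated measurements could easily reverse.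

Compound 3, `COc1cc2ncnc(NNC(=S)NC(=O)c3ccccc3C)c2cc1OC`, keeps the core of compound 1 and changes only the aroyl group: 2-methylphenyl in place of 4-chlorophenyl on a carbonyl carbon. Going by the values given here, no measured pair shows what such an exchange does in this assay, so the expectation rests on the two values alone, both of which lie in the same weak range. The step from compound 1 to compound 3 is expected to be small, a 1.0-fold higher number from compound 1 to compound 3 (0.02 log units; within the scatter), in no settled direction. Compound 3 is therefore estimated at 10000 nM, with a range from 3000 nM to 35000 nM.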

Compound 3, half-maximal inhibitory concentration: 21500 nM
For compound 3 the middle estimate is 2.2-fold (0.33 log units) below the measured one; the measured number falls inside the stated range.
By their numbers in this assay, from the lowest: compounds 2 and 1 (each within the scatter of the next); then compound 3.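

In this assay putting 2-methylphenyl in place of 4-chlorophenyl on a carbonyl carbon gives a 2.2-fold higher number from compound 1 to compound 3 (0.35 log units; beyond the scatter) and so means weaker inhibition, a modest step but one that clears the usual scatter. Going by these compounds alone, compound 1 and compound 2 both carry the 4-chlorophenyl group, so they could say nothing about this position, and this step is the first sign that the aryl group on the carbonyl carbon can shift the cytotoxicity read-out even when the core of compound 1 stays the same. Nothing measured here accounts for the shift, so the data record its direction and size but not its cause.

On these data alone, this single exchange removes the chlorine, brings in a methyl group and moves the substituent from the 4 position of the name to the 2 position, all at once, so the share of each change in the step remains unknown. Values for unsubstituted phenyl, 4-methylphenyl or 2-chlorophenyl at this place would begin to pull those changes apart, and whether any aryl group here can give a clearly lower number than 4-chlorophenyl remains open.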